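The source may report more compounds than this note shows. Statements on the series, on what has been measured and on what is new or still open speak of the compounds shown alone.

Working notes on the series. Compound 3 `Cc1cc(C)c(NC(=O)N(Cc2cccc(-c3cc[nH]n3)c2)C2CCCCCC2)c(C)c1` gives 0.097 mg/kg in a functional assay on a cell-free system (plasma) with sterol O-acyltransferase, Soat (Rattus norvegicus) as the target (on this read-out higher numbers stand for an effect only at larger amounts of compound and lower numbers for an effect already at smaller amounts), the lowest of the two numbers shown; compound 2 `Cc1cc(C)c(NC(=O)N(Cc2cccc(-n3cccc3)c2)C2CCCCCC2)c(C)c1` gives 0.17 mg/kg, and a 1.8-fold lower number from compound 2 to compound 3 (0.24 log units; within the scatter). Compound 1 `Cc1cc(C)c(NC(=O)N(Cc2cccc(-c3nnnn3C)c2)C2CCCCCC2)c(C)c1` reaches only a limit of this assay, > 1 mg/kg. From there, an at least 5.8-fold lower number from compound 1 to compound 2 (0.76 log units; beyond the scatter) and an at least 10-fold lower number from compound 1 to compound 3 (1.01 log units; beyond the scatter), both read against (the limit of > 1 mg/kg in this assay, at which 1 of the 3 values shown sits).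

Compound 4 `Cc1cc(C)c(NC(=O)N(Cc2cccc(-c3ccn(C)n3)c2)C2CCCCCC2)c(C)c1` differs from compound 3 by methyl in place of hydrogen on an aromatic nitrogen. Among the compounds with values here, no measured step changes only an aromatic nitrogen substituent; the steps from compound 1 swap the whole ring, so they bear on this change only loosely. A step of no more than modest size is therefore expected, a 2.1-fold higher number from compound 3 to compound 4 (0.31 log units; beyond the scatter). Compound 4 is estimated at 0.2 mg/kg, with a range of 0.06 mg/kg to 0.7 mg/kg.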

Compound 4, dose for half-maximal effect: < 1 mg/kg
Compound 4 was reported as a limit; the forecaster's own chance of this, stated with the estimate: 10%; the middle value does not contradict the limit.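

Compound 4 stands only as a limit, < 1 mg/kg, in this assay. Its steps from compound 2 and compound 3 cannot be read. Within the data shown here, the one step that can be stated is a number no higher from compound 1 to compound 4 (the limit leaves the size open). Compound 1 is also a limit, > 1 mg/kg, on the opposite side. Compounds 1 and 4 both carry a methyl on an aromatic nitrogen, so that methyl alone does not place a compound with compound 1: the limit of > 1 mg/kg in this assay, at which 1 of the 4 values shown sits.

From the compounds shown here alone, how far the methyl moves the number from compound 3 remains open. Also open, going by these compounds, is what a longer chain such as ethyl, or an amine-bearing chain, would do on this aromatic nitrogen.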